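Replacing a large side group with ethoxycarbonyl

The compounds below may be only part of what the source reports. "The series", "measured", "known", "first", "only" and "open" are said of these compounds alone.

Of the compounds shown here, two with the same core have been measured so far. In an ADME assay on WI-38 cells (Homo sapiens) for cytotoxicity, read by MTT assay, with a stated time of 72 h (a higher number here means a weaker inhibitor, a lower number a stronger inhibitor), compound 1 `O=C(CCc1cccc2c1B(O)OC2)Nc1ccc(I)cc1` gives 49000 nM, while compound 2 `CC(C)(C)OC(=O)NCc1ccc(NC(=O)CCc2cccc3c2B(O)OC3)cc1` gives 4800 nM, the lower of the two numbers. They differ in a single group, with ((tert-butoxycarbonyl)amino)methyl in place of iodo on an aromatic carbon, and the size of that change is clear: a 10-fold lower number from compound 1 to compound 2 (1.01 log units; beyond the scatter).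

Compound 3 `CCOC(=O)c1ccc(NC(=O)CCc2cccc3c2B(O)OC3)cc1` keeps the core but gives up the group that separates compound 2 from compound 1, taking ethoxycarbonyl in its place (ethoxycarbonyl in place of ((tert-butoxycarbonyl)amino)methyl on an aromatic carbon). For the measured compounds named here, only one measured step bears on this change, the large drop of a 10-fold lower number from compound 1 to compound 2 (1.01 log units; beyond the scatter), which came with the arrival of the group now leaving. Losing that group may undo part of the drop, so a higher number is expected in this assay. How ethoxycarbonyl itself behaves has not been measured, and a single step is a thin basis, so the expectation stays wide. The expected change is a 3.8-fold higher number from compound 2 to compound 3 (0.57 log units; beyond the scatter). For compound 3 the estimate is 18000 nM, with an expected range from 5000 nM to 60000 nM.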

Compound 3, half-maximal inhibitory concentration: > 100000 nM
Compound 3: only a limit was reported (the forecaster's own chance of this, stated with the estimate: 5%); at least 5.5-fold (0.74 log units) between middle value and limit.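

The reading for compound 3 in this assay is a limit and not a number: the limit of > 100000 nM in this assay, at which 1 of the 3 values shown sits. Placing ethoxycarbonyl on this aromatic carbon, para to a large group, in place of ((tert-butoxycarbonyl)amino)methyl gives an at least 20-fold higher number from compound 2 to compound 3 (1.31 log units; beyond the scatter), so the low number of compound 2 does not carry over to this other group, and the true size of the step stays unknown. Placing ethoxycarbonyl there in place of iodo gives an at least 2.0-fold higher number from compound 1 to compound 3 (0.30 log units; that floor lies within the scatter), so the data do not firmly separate compound 3 from compound 1, even though compound 2 stands well apart from both.

The compounds shown leave open which feature of ((tert-butoxycarbonyl)amino)methyl goes with the low number of compound 2, since this group and ethoxycarbonyl differ in heavy atoms, in nitrogen and in hydrogen-bond donors all at once. An aminomethyl group or a carboxylic acid on the same aromatic carbon would help to separate these features, by showing whether the number follows the nitrogen-bearing chain or the whole of the larger group.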